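Chloro to amino on the shared core, meta isomer

The source may hold more compounds than are shown below. What is called first, only, known or untested is meant among the compounds shown, and "the series" means these compounds.

Of the compounds shown here, three have been measured in a functional assay on UO-31 cells (Homo sapiens) for cytotoxicity, read by sulforhodamine B assay, with a stated time of 48 h; on this read-out lower numbers stand for stronger inhibition of growth and higher numbers for weaker inhibition of growth. Compound 3 `ClCc1ccc(Cn2cnc3c(Cl)nc(Cl)nc32)cc1` gives 35500 nM, and compound 1 `Nc1nc(Cl)c2ncn(Cc3ccc(CCl)cc3)c2n1` gives 25100 nM. Compound 2 `ClCc1cccc(Cn2cnc3c(Cl)nc(Cl)nc32)c1` gives 3090 nM, the lowest number of the three; compound 1 and compound 3 both stand beyond the scatter above it. The difference between the core of compound 2 and the core of compound 3 is not broken down here.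

The change from compound 3 to compound 1 is amino in place of chloro on an aromatic carbon. It made a step of a 1.4-fold lower number from compound 3 to compound 1 (0.15 log units; within the scatter).

The unmeasured compound 4 `Nc1nc(Cl)c2ncn(Cc3cccc(CCl)c3)c2n1` is reached from compound 2 by amino in place of chloro on an aromatic carbon, the same change, with the same surroundings at the place. Because the measured step of a 1.4-fold lower number from compound 3 to compound 1 (0.15 log units; within the scatter) stays within the scatter, the step from compound 2 to compound 4 in this assay is expected to be similar and small, around a 1.2-fold lower number from compound 2 to compound 4 (0.09 log units; within the scatter). Compound 4 is therefore estimated at 2500 nM in this assay, with a range from 900 nM to 7000 nM, a single precedent being the only basis.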

Compound 4, concentration for total growth inhibition: 32400 nM
Beside the measured number, compound 4's estimate is 13-fold (1.11 log units) below it, outside the stated range (above it).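

In this assay, amino in place of chloro on an aromatic carbon gives a 10-fold higher number from compound 2 to compound 4 (1.02 log units; beyond the scatter), and the same change does not read the same on the two cores: the same change on two cores in this assay, a 1.4-fold lower number (0.15 log units; within the scatter) from compound 3 to compound 1 and a 10-fold higher number (1.02 log units; beyond the scatter) from compound 2 to compound 4, 15-fold (1.17 log units) apart, beyond the scatter of two such steps

A step measured on one core of this series is therefore a poor guide to the same change on the other, and the small step on the core of compound 3 cannot be carried over to the core of compound 2. Going by these compounds alone, this rests on only two pairs, so it sets no rule for further cores and does not show why the two steps part, since the values carry no information on cause.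

The compounds shown leave open how other groups at this place would read, such as a methylamino or a methoxy group, and whether these would also differ between the two cores. They also leave open whether the gap between the steps would persist if the chloromethyl group gave way to a methyl or a hydroxymethyl group.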